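Carboxy for hydroxymethyl on the chain carbon

This account rests on a few compounds, and the source may have more. Where it says the series, first, only, none or still open, it means among the compounds named here.

Compound 1 `CCOC(CCn1c(Cc2nn(C)c(=O)c3ccccc23)nnc1SCC(=O)Nc1ccc(Cl)cc1Cl)OCC` carries diethoxymethyl on a saturated chain carbon, two bonds along the chain from an aromatic nitrogen. In an assay on 32D cells for inhibition of interleukin-15 (Mus musculus), read by resazurin assay, with stated times of 30 min and 2.5 days, in the presence of a further agent that is not named here (on this read-out higher numbers stand for weaker inhibition and lower numbers for stronger inhibition), compound 1 gives only a limit of the assay, > 30000 nM. Compound 2 `Cn1nc(Cc2nnc(SCC(=O)Nc3ccc(Cl)cc3Cl)n2CCCO)c2ccccc2c1=O` has hydroxymethyl at that place. In this assay compound 2 likewise gives only a limit, > 30000 nM. The step that the two limits leave unreadable from compound 1 to compound 2 is therefore unreadable in size. Compound 2 thus sits at the limit of > 30000 nM in this assay, at which 2 of the 2 values shown sit.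

Compound 3 `Cn1nc(Cc2nnc(SCC(=O)Nc3ccc(Cl)cc3Cl)n2CCC(=O)O)c2ccccc2c1=O` is not yet measured and differs from compound 2 by carboxy in place of hydroxymethyl on a saturated chain carbon, two bonds along the chain from an aromatic nitrogen. Among the measured compounds shown here, the single measured step touches the same place but has no readable size, so it gives neither direction nor magnitude to carry over. For compound 3 in this assay the expected result is again a limit rather than a number, and the estimate for compound 3 is 40000 nM, with a range from 15000 nM to 150000 nM. The step expected here, a step that the limit leaves unreadable from compound 2 to compound 3, is accordingly one that a limit would not resolve.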

Compound 3, half-maximal inhibitory concentration: > 30000 nM
Compound 3: a limit, no number; the forecaster's own chance of this, stated with the estimate: 85%; the middle value does not contradict the limit.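

No step can be read from compound 1 or compound 2 to compound 3 in this assay, where all three stand at one limit of the assay, not a number: the limit of > 30000 nM in this assay, at which 3 of the 3 values shown sit.

The compounds shown leave open whether diethoxymethyl, hydroxymethyl and carboxy at this place differ at all in inhibition.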